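Swapping the benzimidazole amide for a fluorophenyl amide

This account rests on a few compounds, and the source may have more. Where it says the series, first, only, none or still open, it means among the compounds named here.

Measured compounds in an assay for inhibition of Indoleamine 2,3-dioxygenase 1 (Homo sapiens), read by HPLC, with a stated time of 48 h; a higher number here means a weaker inhibitor, a lower number a stronger inhibitor:
compound 1, `O=C(NCc1cccc(Cn2cnc3ccccc32)c1)c1cc(Br)c[nH]1`: 16 nM
compound 2, `O=C(NCc1cccc(Cn2cnc3ccccc32)c1)c1cc2ccccc2[nH]1`: 72 nM
compound 3, `O=C(NCc1cccc(Cn2cnc3ccccc32)c1)c1nc2ccccc2[nH]1`: 407 nM

Compound 3 gives the highest number of the three, so it is the weakest inhibitor shown: the step of a 25-fold higher number from compound 1 to compound 3 (1.41 log units; beyond the scatter) is large, and the step of a 5.7-fold higher number from compound 2 to compound 3 (0.75 log units; beyond the scatter) is modest, while a 4.5-fold higher number from compound 1 to compound 2 (0.65 log units; beyond the scatter) lies between the other two compounds. Compound 4, `O=C(NCc1cccc(Cn2cnc3ccccc32)c1)c1ccc(F)cc1`, differs from compound 3 in one place: 4-fluorophenyl in place of 1H-benzimidazol-2-yl on a carbonyl carbon. For the measured compounds named here, none of the measured steps exchanges a ring that carries a hydrogen-bond donor for one that carries none, so the measured steps give no clear direction for this change. The number for compound 4 is therefore expected to stay near that of compound 3, with the step of a 1.6-fold lower number from compound 3 to compound 4 (0.21 log units; within the scatter) estimated to lie within the scatter; compound 4 is estimated at 250 nM, with a range from 50 nM to 1200 nM.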

Compound 4, half-maximal inhibitory concentration: 961 nM
For compound 4 the middle estimate is 3.8-fold (0.58 log units) below the measured one, within the range that was stated.
By their numbers in this assay, from the lowest: compound 1; then compound 2; then compound 3; then compound 4.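

Among the rings shown on this carbonyl carbon, 4-fluorophenyl is the only one without a hydrogen-bond donor, and it gives the highest number so far, with a 2.4-fold higher number from compound 3 to compound 4 (0.37 log units; beyond the scatter) and a 13-fold higher number from compound 2 to compound 4 (1.13 log units; beyond the scatter) and a 60-fold higher number from compound 1 to compound 4 (1.78 log units; beyond the scatter) as its steps. At this place, then, all three donor-bearing rings give stronger inhibitors than 4-fluorophenyl, though they also differ widely among themselves. Nothing measured here explains this difference.

From the compounds shown here alone, whether the loss follows the missing donor, the fluorine or the change of ring stays open. A plain phenyl ring, or a phenyl ring carrying an amine, could help separate these.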